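Aryl Amides and a Thiophene Variant in Channel Binding

The source may hold more compounds than are shown below. What is called first, only, known or untested is meant among the compounds shown, and "the series" means these compounds.

Compound 1, `CCCC(C)C(=O)Nc1c(C(O)(C(F)(F)F)C(F)(F)F)ccc2ccccc12`: in an assay on LtK cells with ATP-sensitive inward rectifier potassium channel 11 (Homo sapiens) as the target (a higher number here means that more compound is needed for the effect, a lower number that less compound is needed), compound 1 gives only an assay limit, > 10000 nM.
Compound 2, `Cc1ccc(C(=O)Nc2c(C(O)(C(F)(F)F)C(F)(F)F)ccc3ccccc23)cc1`: in this assay compound 2 gives 76 nM.
Compound 3, `COc1ccc(C(=O)Nc2c(C(O)(C(F)(F)F)C(F)(F)F)ccc3ccccc23)cc1`: in this assay compound 3 gives 417 nM.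

Compound 3 stands highest of the two numbers shown; its nearest neighbour is compound 2, and the step reads a 5.5-fold higher number from compound 2 to compound 3 (0.74 log units; beyond the scatter). The remaining value is a limit, (the limit of > 10000 nM in this assay, at which 1 of the 3 values shown sits). Compound 4, `O=C(Nc1c(C(O)(C(F)(F)F)C(F)(F)F)ccc2ccccc12)c1cccs1`, is not yet measured. It differs from compound 3 in one place: thiophen-2-yl in place of 4-methoxyphenyl on a carbonyl carbon.

Within the data shown here, two measured steps bear on this change. Replacing the 1-methylbutyl chain by an aromatic ring gave an at least 130-fold lower number from compound 1 to compound 2 (2.11 log units; beyond the scatter) and an at least 23-fold lower number from compound 1 to compound 3 (1.37 log units; beyond the scatter), so an aromatic group on the carbonyl carbon is strongly favoured. Within the aromatic pair, the methoxy gave a 5.5-fold higher number from compound 2 to compound 3 (0.74 log units; beyond the scatter). Thiophen-2-yl is an unsubstituted aromatic ring, so compound 4 is expected to sit among the aromatic amides. For compound 4 the expected step is a modest one, estimated as a 2.1-fold lower number from compound 3 to compound 4 (0.32 log units; beyond the scatter). Compound 4 is therefore estimated at 200 nM, with a range from 50 nM to 1000 nM.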

Compound 4, half-maximal effective concentration: 12 nM
The estimate for compound 4 lay 17-fold (1.22 log units) above the measured number; measured number below the stated range.
By their numbers in this assay, from the lowest: compound 4; then compound 2; then compound 3. At a limit, above all of these: compound 1.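

At this carbonyl carbon a six-membered aromatic ring is not required: the five-membered thiophen-2-yl, with fewer heavy atoms, gives a 35-fold lower number from compound 3 to compound 4 (1.54 log units; beyond the scatter) and a 6.3-fold lower number from compound 2 to compound 4 (0.80 log units; beyond the scatter), so it outperforms both substituted phenyl rings. Among these compounds, the earlier compounds showed only that aromatic rings were preferred over the 1-methylbutyl chain, and this gap now widens to an at least 830-fold lower number from compound 1 to compound 4 (2.92 log units; beyond the scatter). That step gives only a minimum, as compound 1 stands at a limit of the assay: the limit of > 10000 nM in this assay, at which 1 of the 4 values shown sits.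

Which of the ring size, the ring sulfur or the missing substituent carries the gain stays open; an unsubstituted phenyl, a furan-2-yl or a thiophen-3-yl group on the same carbonyl carbon would speak to that. Also open, going by these compounds, is how a chlorine or methyl group on the thiophene ring would read in this assay.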